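Hydroxy on the phenyl of compound 2

A few compounds are considered here, and "the series" means these few. Any claim that something is new, unique, unknown or untested is made for them only; others in the source may bear on it.

In a functional assay on QG-56 cells (Homo sapiens) for cytotoxicity, read by MTT assay, with a stated time of 48 h (a lower number here means a stronger inhibitor, a higher number a weaker inhibitor), compound 1 (`COc1cc(/C=C/C(=O)C2=C(/C=C/c3ccc(O)c(OC)c3)NC(=O)NC2c2cccc([N+](=O)[O-])c2)ccc1O`) gives 25000 nM. Compound 2 (`COc1cc(/C=C/C(=O)C2=C(/C=C/c3ccc(O)c(OC)c3)NC(=S)NC2c2ccccc2)ccc1O`) gives 100000 nM, the higher of the two numbers, with a gap to compound 1 beyond the scatter. Compound 3 (`COc1cc(/C=C/C(=O)C2=C(/C=C/c3ccc(O)c(OC)c3)NC(=S)NC2c2ccccc2O)ccc1O`) departs from compound 2 in one place: hydroxy in place of hydrogen on an aromatic carbon, phenyl to 2-hydroxyphenyl. Among the measured compounds shown here, no measured pair shows this change, so the expectation is weak. The expected step is a 2.0-fold lower number from compound 2 to compound 3 (0.30 log units; within the scatter), toward a lower number and close to the scatter. For compound 3 the estimated value is 50000 nM, with an expected range of 15000 nM to 130000 nM.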

Compound 3, half-maximal inhibitory concentration: 50000 nM
Compound 3: middle estimate and measured number agree at the digits printed; the measured number falls inside the stated range.
By their numbers in this assay, from the lowest: compounds 1, 3 and 2 (each within the scatter of the next, the first and the last beyond it).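

In this assay, the first measured case of hydroxy in place of hydrogen on an aromatic carbon, ortho to a large group, gives a 2.0-fold lower number from compound 2 to compound 3 (0.30 log units; within the scatter). On this evidence, phenyl to 2-hydroxyphenyl leaves the number within the scatter, so this position tolerates the hydroxy but shows no clear gain from it. No available evidence bears on the size of this step.

On these data alone, whether a methoxy, an amine or a carboxylic acid at this position would give a step beyond the scatter remains open. A single pair also leaves open whether the same change behaves alike on other members of the series.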